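The source may hold more compounds than are shown below. What is called first, only, known or untested is meant among the compounds shown, and "the series" means these compounds.

In a functional assay on the whole organism (strain Sprague-Dawley) for inhibition, with Rattus norvegicus as the target, with a stated time of 10 min (on this read-out higher numbers stand for an effect only at larger amounts of compound and lower numbers for an effect already at smaller amounts), compound 1 (`CCOc1ccc(OC)cc1-c1ncc(C(=O)O)c(=O)[nH]1`) gives 0.2 mg/kg and compound 3 (`CCOc1ccc(N(C)C)cc1-c1ncc(C(=O)O)c(=O)[nH]1`) gives 0.3 mg/kg at the low end of the numbers, a pair within the scatter of each other (a 1.5-fold higher number from compound 1 to compound 3 (0.18 log units; within the scatter)). Compound 2 (`CCOc1ccc([N+](=O)[O-])cc1-c1ncc(C(=O)O)c(=O)[nH]1`) lies far off at 25 mg/kg (a 130-fold higher number from compound 1 to compound 2 (2.10 log units; beyond the scatter)).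

Compound 4 (`CCOC(=O)c1cnc(-c2cc(OC)ccc2OCC)[nH]c1=O`) differs from compound 1 in one place, where carboxy becomes ethoxycarbonyl (ethyl in place of hydrogen on an oxygen next to a carbonyl group). Within the data shown here, no measured step touches that place, since all of them swap groups on an aromatic carbon. Among the measured compounds shown here, they show only that a single swap can change almost nothing or a great deal, as with the return from nitro to dimethylamino (an 83-fold lower number from compound 2 to compound 3 (1.92 log units; beyond the scatter)). The size of the new step therefore stays uncertain. With compound 1 at 0.2 mg/kg already at the low end, a higher number is the likelier direction in this assay and a moderate rise is expected (a 7.5-fold higher number from compound 1 to compound 4 (0.88 log units; beyond the scatter)). Compound 4 is expected to give an estimated 1.5 mg/kg (range 0.2 mg/kg to 15 mg/kg).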

Compound 4, dose for 50% inhibition: 0.3 mg/kg
Compound 4: the middle estimate sits 5.0-fold (0.70 log units) above what was measured; measured number inside the range.
By their numbers in this assay, from the lowest: compounds 1, 3 and 4 (each within the scatter of the next); then compound 2.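

Ethyl in place of hydrogen on an oxygen next to a carbonyl group gives a 1.5-fold higher number from compound 1 to compound 4 (0.18 log units; within the scatter) in this assay and so leaves the two compounds within the scatter of each other. Among these compounds, the earlier compounds differed only on an aromatic carbon, so this is the first sign that the carboxy group can become ethoxycarbonyl and the dose stay at the low end of the numbers, which means the hydrogen on that oxygen is not required for a low number in the whole animal. No measurement shown here explains why the two compounds lie so close.

From the compounds shown here alone, whether other groups are accepted at this place remains open, for example a longer chain such as butyl on the same oxygen, or an amide in place of the carboxy group. Going by these compounds, it is also open whether ethoxycarbonyl would give the same result alongside the nitro group of compound 2.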